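The source may report more compounds than this note shows. Statements on the series, on what has been measured and on what is new or still open speak of the compounds shown alone.

Measured compounds in a toxicity assay on THP-1 cells (Homo sapiens) for inhibition; a lower number here means that less compound is tolerated, a higher number that more compound is tolerated:

Compound 1 `COc1ccc(-c2cnc(NC(=O)c3cnc[nH]3)n2C)cc1` — compound 1 gives > 100000 nM, a limit of the assay and not a number.
Compound 2 `Cn1c(-c2ccccc2[N+](=O)[O-])cnc1NC(=O)c1ccc(F)cc1` — compound 2 gives 31000 nM.
Compound 3 `COc1ccc2c(c1)nc(NC(=O)c1ccc(F)cc1)n2C` — compound 3 gives > 100000 nM, likewise a limit of the assay.

Compound 1 stands at the limit of > 100000 nM in this assay, at which 2 of the 3 values shown sit. For the measured compounds named here, no step between measured compounds differing in a single place is available, so nothing in this set shows how a single change moves the read-out; compound 2 is the only one reported as a number, and it sits well within the tolerated range.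

Compound 4 `COc1ccc(-c2cnc(NC(=O)c3cccc(C)c3)n2C)cc1` is yet to be measured. It differs from compound 1 in one place: 3-methylphenyl in place of 1H-imidazol-5-yl on a carbonyl carbon. With compound 1 at the limit, the expectation for this assay is a step of an at least 1.4-fold lower number from compound 1 to compound 4 (0.15 log units; that floor lies within the scatter) that stays within the scatter or moves slightly toward less tolerance, and no more, since compound 3, also carrying an aromatic carbon ring on the carbonyl, reports only a limit. Compound 4 is therefore estimated at 70000 nM, with a range from 20000 nM to 200000 nM.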

Compound 4, half-maximal cytotoxic concentration: > 100000 nM
Compound 4 gave a limit, no number; the forecaster's own chance of this, stated with the estimate: 55%; middle value at least 1.4-fold (0.15 log units) away from the limit.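

In this assay, for the compounds shown here, compound 1 and compound 4 each report only a limit of the assay, so no step between them can be read. The compounds shown leave open whether 3-methylphenyl in place of 1H-imidazol-5-yl on a carbonyl carbon moves this read-out at all.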